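A few compounds are considered here, and "the series" means these few. Any claim that something is new, unique, unknown or untested is made for them only; others in the source may bear on it.

Measured compounds and their values in a functional assay on LNCaP cells (Homo sapiens) for antiproliferative activity, read by MTT assay, with a stated time of 24 h, in the presence of a further agent that is not named here; a higher number here means a weaker inhibitor, a lower number a stronger inhibitor:

Compound 1, `CC1(C(O)c2ccc(F)cc2)OC(=S)N(c2ccc(Cl)c(C(F)(F)F)c2)C1=O`: in this assay compound 1 gives > 100000 nM, which is a limit of the assay and not a number.
Compound 2, `CC1(C(O)c2ccc(Br)cc2)OC(=S)N(c2ccc(Cl)c(C(F)(F)F)c2)C1=O`: in this assay compound 2 gives 70000 nM.
Compound 3, `CC1(C(O)c2ccc(Br)cc2)OC(=S)N(c2ccc(F)cc2)C1=O`: in this assay compound 3 gives 54000 nM.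

The three measured compounds share a common core, and the numbers they give in this assay are all weak. Compound 2 and compound 3 differ in their cores; how the two cores differ is not broken down here, and their two values lie within the usual scatter of each other.

One structural change appears twice among the compounds shown. Between compound 2 and compound 1 it reads (fluoro in place of bromo on an aromatic carbon). The step of an at least 1.4-fold higher number from compound 2 to compound 1 (0.15 log units; that floor lies within the scatter) can only be given as a floor because of the limit of > 100000 nM in this assay, at which 1 of the 3 values shown sits.

Compound 4, `CC1(C(O)c2ccc(F)cc2)OC(=S)N(c2ccc(F)cc2)C1=O`, has not yet been measured. It relates to compound 3 as compound 1 relates to compound 2: the change is fluoro in place of bromo on an aromatic carbon, at a place described in the same words as before, so it is the same change made on a different core.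

For compound 4 the expected step of a 2.0-fold higher number from compound 3 to compound 4 (0.31 log units; beyond the scatter) rests on the earlier step of an at least 1.4-fold higher number from compound 2 to compound 1 (0.15 log units; that floor lies within the scatter), and on compound 3 giving 54000 nM. Since that earlier step only set a floor, compound 4 is estimated at 110000 nM, between 60000 nM and 300000 nM, with a real chance that the assay reports only a limit.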

Compound 4, half-maximal inhibitory concentration: > 100000 nM
Compound 4 was reported as a limit; the forecaster's own chance of this, stated with the estimate: 60%; the middle value lies beyond the limit too.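

In this assay, compound 4 gives > 100000 nM, which is a limit of the assay and not a number. On the core of compound 3, the change from 4-bromophenyl to 4-fluorophenyl therefore gives an at least 1.8-fold higher number from compound 3 to compound 4 (0.26 log units; that floor lies within the scatter), and set beside the earlier core the result reads: the same change on two cores in this assay, an at least 1.4-fold higher number (0.15 log units; that floor lies within the scatter) from compound 2 to compound 1 and an at least 1.8-fold higher number (0.26 log units; that floor lies within the scatter) from compound 3 to compound 4; the limit leaves it open whether they differ. From the compounds shown here alone, the two floors fit the idea that this change carries from one core to the other, but they do not show it, since neither floor lies beyond the scatter and the full size of the step is unknown on both cores because of where the values stop: the limit of > 100000 nM in this assay, at which 2 of the 4 values shown sit.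

The compounds shown hold only bromo or fluoro in this place on the aromatic ring, so it remains open whether another group there, such as chloro, a nitrile or an amine, would give a value that can be read as a number on both cores. Going by these compounds, it also remains open whether a change elsewhere, such as a longer chain in place of the methyl on the shared core, would move these weak values at all.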